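This account rests on a few compounds, and the source may have more. Where it says the series, first, only, none or still open, it means among the compounds named here.

Compound 1 `O=C(NO)C(F)(F)C(F)(F)C(F)(F)C(F)(F)C(F)(F)C(F)(F)C(=O)Nc1ccc(I)cc1` pairs a long fluorinated chain, capped at one end by a hydroxamic acid, with an amide whose nitrogen carries a 4-iodophenyl group. In an ADME assay on isolated protein for inhibition of histone deacetylase 5 (Homo sapiens), read by fluorescence, with stated times of 30 min and 60 min (a higher number here means a weaker inhibitor, a lower number a stronger inhibitor), compound 1 gives > 50000 nM, which is a limit of the measurement and not a measured number. Compound 2 `O=C(NO)C(F)(F)C(F)(F)C(F)(F)C(F)(F)C(F)(F)C(F)(F)C(=O)Nc1cccc(-c2cn(-c3ccccc3)nn2)c1` keeps the same chain and amide and carries a different aromatic group on the amide-type nitrogen. In this assay compound 2 gives > 50000 nM, again only a limit. The picture so far is summed up by the limit of > 50000 nM in this assay, at which 2 of the 2 values shown sit, so compound 1 stands at the edge of what the assay can report, with nothing to rank it against.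

Compound 3 `O=C(NO)C(F)(F)C(F)(F)C(F)(F)C(F)(F)C(F)(F)C(F)(F)C(=O)Nc1nc(-c2ccccc2)cs1` is built from compound 1 by the change (4-phenyl-1,3-thiazol-2-yl in place of 4-iodophenyl on an amide-type nitrogen). For the measured compounds named here, no measured pair shows what such a swap does here. Because both measured compounds rest at the limit (the limit of > 50000 nM in this assay, at which 2 of the 2 values shown sit), the step of a number no higher from compound 1 to compound 3 (the limit leaves the size open) is expected to be none beyond the usual scatter. Compound 3 is therefore estimated at 50000 nM, with a range from 10000 nM to 200000 nM, most likely reported again as a limit.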

Compound 3, inhibition constant: > 50000 nM
Compound 3: a limit, no number; the forecaster's own chance of this, stated with the estimate: 75%; the middle value lies on the limit itself.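

Compound 3, like compound 1, rests at a limit of the measurement and not at a number, so no step can be read between compound 1 and compound 3: the limit of > 50000 nM in this assay, at which 3 of the 3 values shown sit. The compounds shown leave open which group on the amide-type nitrogen, if any, would give a readable number in this assay.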